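This account rests on a few compounds, and the source may have more. Where it says the series, first, only, none or still open, it means among the compounds named here.

Measured so far in a physicochemical assay for solubility, with a stated time of 18 h, at pH 7.4; a higher number here means a more soluble compound, a lower number a less soluble compound:
compound 1 `COc1ccc(F)cc1CNCCCNc1ccnc2cc(Cc3ccc(F)cc3Cl)ccc12`, 4200 nM
compound 2 `COc1cccc(CNCCCNc2ccnc3cc(Cc4ccc(F)cc4)ccc23)c1O`, 4200 nM
compound 3 `Fc1ccc(Cc2ccc3c(NCCCNCc4ccco4)ccnc3c2)c(Cl)c1`, 4200 nM

Compound 1 stands level with compounds 2 and 3 at the digits shown; all three values are the same number, so nothing separates them within this assay. Among the measured compounds shown here, the one measured step, no change at the digits printed from compound 1 to compound 3 (within the scatter), touched the other end of the shared core and did not move solubility beyond the scatter. Compound 2 differs from compound 1 in two places and shows the same value.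

Compound 4 `COc1ccc(F)cc1CNCCCNc1ccnc2cc(Oc3ccccc3)ccc12` carries the change (phenoxy in place of 2-chloro-4-fluorobenzyl on an aromatic carbon). For the measured compounds named here, no measured step bears on this position. Without a step to lean on, the expectation for compound 4 is solubility near compound 1, no change at the digits printed from compound 1 to compound 4 (within the scatter), and the estimate is 4200 nM, with a range from 2000 nM to 8500 nM.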

Compound 4, solubility: 14500 nM
Estimate against measurement, compound 4: 3.5-fold (0.54 log units) below; measured number outside the range, above it.
By their numbers in this assay, from the lowest: compounds 1, 2 and 3 (each within the scatter of the next); then compound 4.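

In this assay, the aromatic carbon bearing 2-chloro-4-fluorobenzyl is the only position shown where a change moves the read-out beyond the scatter: with phenoxy in that place, the step is a 3.5-fold higher number from compound 1 to compound 4 (0.54 log units; beyond the scatter) on the shared core. By contrast, the change at the other end, no change at the digits printed from compound 1 to compound 3 (within the scatter), left the value level. No measurement available explains the rise at this position.

As far as these compounds go, the step exchanges the link to the ring and the ring's chlorine and fluorine together, so their separate contributions remain open. An unsubstituted benzyl or a phenylamino group on this carbon would separate them.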